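The compounds below may be only part of what the source reports. "The series", "measured", "known", "first", "only" and "open" are said of these compounds alone.

In a functional assay on the whole organism with Rattus norvegicus as the target (a lower number here means that less compound is needed, a higher number that more compound is needed for the effect), the measured compounds differ only in the chain on the aromatic oxygen. Compound 1 (`CCCOc1ccccc1-c1ncc(-c2nn[nH]n2)c(O)n1`) gives 0.04 mg/kg and stands at the low end of the numbers, level with compound 3 (`Oc1nc(-c2ccccc2OCC2CC2)ncc1-c1nn[nH]n1`), which gives 0.07 mg/kg in a step (a 1.8-fold higher number from compound 1 to compound 3 (0.24 log units; within the scatter)) inside the scatter. Compound 2 (`CCCCCOc1ccccc1-c1ncc(-c2nn[nH]n2)c(O)n1`) gives 0.4 mg/kg and lies clear of both (a 10-fold higher number from compound 1 to compound 2 (1.00 log units; beyond the scatter)) and (a 5.7-fold lower number from compound 2 to compound 3 (0.76 log units; beyond the scatter)). Compound 4 (`CCCOc1ccc(OC)cc1-c1ncc(-c2nn[nH]n2)c(O)n1`) keeps the propoxy group of compound 1 and changes the aromatic ring instead (methoxy in place of hydrogen on an aromatic carbon). Among the measured compounds shown here, no measured step covers a change on that ring, so the chain steps bear on it only indirectly, as a guide to the sizes seen. A small upward step in this assay is expected, not clearly beyond the scatter and smaller than the modest chain step (a 10-fold higher number from compound 1 to compound 2 (1.00 log units; beyond the scatter)) to compound 2. Expected for this change is a 1.8-fold higher number from compound 1 to compound 4 (0.24 log units; within the scatter) as an estimate only. For compound 4 the estimate is 0.07 mg/kg with an expected range from 0.02 mg/kg to 0.3 mg/kg in this assay.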

Compound 4, dose for 50% inhibition: 0.03 mg/kg
Compound 4: the middle estimate sits 2.3-fold (0.37 log units) above what was measured, within the range that was stated.
By their numbers in this assay, from the lowest: compounds 4, 1 and 3 (each within the scatter of the next, the first and the last beyond it); then compound 2.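

On the six-membered aromatic ring, methoxy in place of hydrogen, para to a propoxy group, leaves compound 4 level with compound 1 in this assay (a 1.3-fold lower number from compound 1 to compound 4 (0.12 log units; within the scatter)). Among the compounds shown here, this is the first reading from the ring rather than the chain on the aromatic oxygen, and it shows that this carbon accepts methoxy, whereas the chain change gave a step beyond the scatter (a 10-fold higher number from compound 1 to compound 2 (1.00 log units; beyond the scatter)). No supporting data bear on why the ring change leaves the number within the scatter.

Open, from the compounds shown here alone, is whether this carbon also accepts an amine, a carboxylic acid or a longer alkoxy chain, and whether the other ring carbons accept methoxy. Also open, going by these compounds, is whether methoxy stays level when paired with the chain of compound 2 or compound 3.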